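The source may hold more compounds than are shown below. What is called first, only, known or untested is meant among the compounds shown, and "the series" means these compounds.

In an assay for inhibition of Fatty-acid amide hydrolase 1 (Rattus norvegicus) (on this read-out lower numbers stand for stronger inhibition and higher numbers for weaker inhibition), three compounds have numbers or limits so far. Compound 3 `CN(C)C(=O)c1cnc(C(=O)CCc2ccc(Oc3ccccc3)cc2)o1` gives 5.4 nM. Compound 2 `O=C(O)c1ccc(-c2cnc(C(=O)CCc3ccc(-c4ccccc4)cc3)o2)cn1` gives 44 nM, the higher of the two numbers shown, and the gap to compound 3 lies beyond the usual scatter, so compound 2 is the weaker inhibitor of that pair. Compound 1 `NC(=O)c1ccc(-c2cnc(C(O)CCc3ccc(-c4ccccc4)cc3)o2)nc1` yields only a limit in this assay, > 1000 nM, not a number.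

Compound 4 `O=C(O)c1cc(-c2cnc(C(=O)CCc3ccc(-c4ccccc4)cc3)o2)ccn1` has not yet been measured. It differs from compound 2 in one place: 2-carboxypyridin-4-yl in place of 6-carboxypyridin-3-yl on an aromatic carbon. The two molecules contain the same atoms; only the way the carboxylic acid and the ring nitrogen are arranged on that pyridine ring changes. Going by the values given here, no measured pair shows a rearrangement of this kind, so its effect cannot be read from the data. With everything else kept as in compound 2, the step from compound 2 to compound 4 is expected to be modest, a 2.0-fold higher number from compound 2 to compound 4 (0.31 log units; beyond the scatter), leaning toward slightly weaker inhibition but possibly within the scatter. Compound 4 is therefore estimated at 90 nM, with a likely range from 25 nM to 350 nM.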

Compound 4, inhibition constant: 50 nM
The estimate for compound 4 lay 1.8-fold (0.26 log units) above the measured number; the measured number falls inside the stated range.
By their numbers in this assay, from the lowest: compound 3; then compounds 2 and 4 (each within the scatter of the next). At a limit, above all of these: compound 1.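

In this assay, rearranging the carboxylic acid and the ring nitrogen on this pyridine, with 2-carboxypyridin-4-yl in place of 6-carboxypyridin-3-yl, gives a 1.1-fold higher number from compound 2 to compound 4 (0.06 log units; within the scatter). The earlier compounds shown here held no pair of this kind, and this pair shows that, on the aromatic carbon next to the ring oxygen, these two arrangements of the same atoms cannot be told apart in this read-out. Nothing in the data shown explains why the two arrangements read alike.

The compounds shown leave open how a methyl ester or an amine in place of the carboxylic acid on this pyridine would read, and so whether the acid is needed here at all. They also leave open whether a phenyl ring bearing the carboxylic acid, with no ring nitrogen, would read like compound 2 and compound 4.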